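Adding a Chloro Group to the Weakest Analogue

The source may hold more compounds than are shown below. What is called first, only, known or untested is meant among the compounds shown, and "the series" means these compounds.

Compound 3 `Cc1cc(C(=O)O)nn1Cc1cc(Br)ccc1OCc1cccc(C(F)(F)F)c1` gives 1100 nM in a functional assay on CHO-K1 cells for antagonist activity at prostaglandin E2 receptor EP1 subtype (Homo sapiens), read by FLIPR (a lower number here means a stronger inhibitor, a higher number a weaker inhibitor), the highest of the three numbers recorded in this series. Compound 2 `Cc1cccc(COc2ccc(Br)cc2Cn2nc(C(=O)O)cc2C)c1` gives 525 nM, and compound 1 `Cc1cc(C(=O)O)nn1Cc1cc(Br)ccc1OCc1ccc(Cl)cc1` gives 8.71 nM. The step of a 2.1-fold higher number from compound 2 to compound 3 (0.32 log units; beyond the scatter) is modest, whereas the step of a 60-fold higher number from compound 1 to compound 2 (1.78 log units; beyond the scatter) is large. Compound 4 `Cc1cc(C(=O)O)nn1Cc1cc(Br)ccc1OCc1ccc(Cl)c(C(F)(F)F)c1` differs from compound 3 by chloro in place of hydrogen on an aromatic carbon, the chloro entering on an aromatic carbon of a six-membered aromatic ring of carbon only, ortho to a trifluoromethyl group and para to a large group. For the measured compounds named here, no measured step swaps a hydrogen for a chloro directly. The bearing comes from a 60-fold higher number from compound 1 to compound 2 (1.78 log units; beyond the scatter), where a chloro-bearing ring gave a far lower number than a methyl-bearing one, and from the modest 2.1-fold higher number from compound 2 to compound 3 (0.32 log units; beyond the scatter). A clear move toward lower numbers is therefore expected for compound 4, namely an 18-fold lower number from compound 3 to compound 4 (1.26 log units; beyond the scatter). Compound 4 is estimated at 60 nM, with a likely range from 12 nM to 300 nM.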

Compound 4, inhibition constant: < 2000 nM
Compound 4 ended at the assay's limit; the forecaster's own chance of this, stated with the estimate: 5%; the middle value does not contradict the limit.
By their numbers in this assay, from the lowest: compound 1; then compound 2; then compound 3.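

In this assay compound 4 gives < 2000 nM, which is a limit of the assay and not a number, so its steps from compound 3 and from compound 1 cannot be read. The compounds shown leave open which way, and how far, either added group moves the number.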